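Methoxy for hydrogen on the core of compound 1

A few compounds are considered here, and "the series" means these few. Any claim that something is new, unique, unknown or untested is made for them only; others in the source may bear on it.

Measured compounds:
compound 1, `Oc1ccccc1/C=N/c1ccc(OCc2ccccc2)cc1`: 25100 nM
compound 2, `Oc1ccc(F)cc1/C=N/c1ccc(OCc2ccccc2)cc1`: 15300 nM
compound 3, `Oc1cc(O)c(/C=N/c2ccc(OCc3ccccc3)cc2)c(O)c1`: 10100 nM

In an assay on isolated protein for inhibition of Amine oxidase [flavin-containing] B (Homo sapiens), read by fluorescence and Amplex Red, with stated times of 15 min and 20 min (on this read-out higher numbers stand for weaker inhibition and lower numbers for stronger inhibition), compound 1 stands at the top of the three numbers. Compound 2 is nearest, a 1.6-fold lower number from compound 1 to compound 2 (0.21 log units; within the scatter), so the two are not separated; compound 3 is furthest, its value lying beyond the scatter from that of compound 1. Compound 4, `COc1ccc(/C=N/c2ccc(OCc3ccccc3)cc2)c(O)c1`, is not yet measured. It differs from compound 1 by methoxy in place of hydrogen on an aromatic carbon. Among the compounds with values here, only the step to compound 2 changes one place, and it stays within the scatter; no measured step involves a methoxy group, and compound 3 differs from compound 1 in more than one place. The step expected from this change is a 1.4-fold lower number from compound 1 to compound 4 (0.14 log units; within the scatter), not one beyond the scatter. For compound 4 the estimate in this assay is 18000 nM, within 7000 nM to 45000 nM.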

Compound 4, half-maximal inhibitory concentration: 23600 nM
The estimate for compound 4 lay 1.3-fold (0.12 log units) below the measured number; low and high end bracket the measured number.
By their numbers in this assay, from the lowest: compounds 3, 2, 4 and 1 (each within the scatter of the next, the first and the last beyond it).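

In this assay, methoxy in place of hydrogen on this aromatic carbon, meta to a hydroxy group and para to a large group, does not separate the two compounds (a 1.1-fold lower number from compound 1 to compound 4 (0.03 log units; within the scatter)). This gives the series its first single-place step with a group of more than one heavy atom, and it stays within the scatter, as does the fluoro step (a 1.6-fold lower number from compound 1 to compound 2 (0.21 log units; within the scatter)). No supporting data bear on the reason for this result.

Still open, from the compounds shown here alone, is what an amine, a carboxylic acid or a longer chain such as ethoxy would give at this position. Also open, going by these compounds, is whether methoxy elsewhere on the shared core would give a step beyond the scatter.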